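Swapping one dihydroxyphenyl group for another on a shared core

The compounds below may be only part of what the source reports. "The series", "measured", "known", "first", "only" and "open" are said of these compounds alone.

In a functional assay on MCF7 cells (Homo sapiens) for inhibition, read by MTT assay, with a stated time of 72 h (on this read-out higher numbers stand for an effect only at larger amounts of compound and lower numbers for an effect already at smaller amounts), compound 1 `CC1(C)CCC[C@]2(C)[C@@H](Cc3cc(C(=O)O)ccc3O)[C@](C)(O)CC[C@@H]12` gives 50000 nM and compound 2 `CC1(C)CCC[C@]2(C)[C@@H](Cc3ccc(O)cc3O)[C@](C)(O)CC[C@@H]12` gives 11900 nM, the lower of the two numbers. Compound 3 `CC1(C)CCC[C@]2(C)[C@@H](Cc3c(O)cccc3O)[C@](C)(O)CC[C@@H]12` has not yet been measured. It carries 2,6-dihydroxyphenyl in place of 2,4-dihydroxyphenyl on a saturated chain carbon bound to a saturated ring carbon. For the measured compounds named here, no measured pair shows what a change of this kind does in this assay, so no shift beyond the scatter is expected. The expected result is a small step of a 1.2-fold higher number from compound 2 to compound 3 (0.07 log units; within the scatter), toward a slightly higher number. For compound 3, the estimated value is 14000 nM, with an expected range of 6000 nM to 35000 nM.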

Compound 3, half-maximal effective concentration: 16000 nM
Beside the measured number, compound 3's estimate is 1.1-fold (0.06 log units) below it; low and high end bracket the measured number.
By their numbers in this assay, from the lowest: compounds 2 and 3 (each within the scatter of the next); then compound 1.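

In this assay, 2,6-dihydroxyphenyl in place of 2,4-dihydroxyphenyl gives a 1.3-fold higher number from compound 2 to compound 3 (0.13 log units; within the scatter) and so cannot be told apart from the original group. For the compounds shown here, this is the first single change that can be read on a saturated chain carbon bound to a saturated ring carbon, and rearranging the two hydroxyl groups on the ring does not separate the two compounds. No measurement shown here bears on why this is so.

From the compounds shown here alone, it remains open whether methoxy groups or an amine in place of the hydroxyl groups would give a different number. A phenyl ring without hydroxyl groups also remains untested among the compounds shown.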